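Fluorophenyl sulfonyl series: the step to compound 3

The source may hold more compounds than are shown below. What is called first, only, known or untested is meant among the compounds shown, and "the series" means these compounds.

In a functional assay on NSCLC cells (Homo sapiens) for inhibition, read by sulforhodamine B assay, with a stated time of 48 h (a lower number here means a stronger inhibitor, a higher number a weaker inhibitor), compound 1 (`CN1CCCN(CCNc2nccc(-c3c(-c4cccc(O)c4)nc4sccn34)n2)S1(=O)=O`) gives 13600 nM and compound 2 (`O=S(=O)(NCCCNc1nccc(-c2c(-c3cccc(O)c3)nc3sccn23)n1)c1cccc(F)c1`) gives 2550 nM. Compound 2 therefore holds the lower of the two numbers and is the stronger inhibitor of the pair.

Next is compound 3 (`O=S(=O)(NCCNc1nccc(-c2c(-c3cccc(O)c3)nc3sccn23)n1)c1ccc(F)cc1`). The change is ((4-fluorophenyl)sulfonyl)amino in place of (((3-fluorophenyl)sulfonyl)amino)methyl on a saturated chain carbon, two bonds along the chain from a nitrogen on an aromatic ring.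

For the measured compounds named here, only one measured step bears on this, and only indirectly. It is a modest one, a 5.3-fold lower number from compound 1 to compound 2 (0.73 log units; beyond the scatter), and it came with a six-membered aromatic ring of carbon only replacing a six-membered non-aromatic ring with hetero atoms. Compound 3 keeps the aromatic ring, so that gain is not expected to be lost. Going by the values given here, no measured step isolates the fluorine position or the removed methyl, so no direction can be argued with confidence.

The expected step is a 1.2-fold higher number from compound 2 to compound 3 (0.07 log units; within the scatter), which means none beyond the scatter in this assay. Compound 3 is estimated at 3000 nM with an expected range of 1000 nM to 9000 nM.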

Compound 3, half-maximal inhibitory concentration: 3260 nM
For compound 3 the middle estimate is 1.1-fold (0.04 log units) below the measured one; the range from low to high includes it.
By their numbers in this assay, from the lowest: compounds 2 and 3 (each within the scatter of the next); then compound 1.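

In this assay, the step of a 1.3-fold higher number from compound 2 to compound 3 (0.11 log units; within the scatter) shows that ((4-fluorophenyl)sulfonyl)amino in place of (((3-fluorophenyl)sulfonyl)amino)methyl on this saturated chain carbon gives no difference that can be resolved from the scatter, so this combined change is tolerated in this assay. The step of a 4.2-fold lower number from compound 1 to compound 3 (0.62 log units; beyond the scatter) sits beside a 5.3-fold lower number from compound 1 to compound 2 (0.73 log units; beyond the scatter), which gives two fluorophenyl sulfonyl compounds, each with a six-membered aromatic ring of carbon only, that stand apart from compound 1 beyond the scatter, and the earlier gain is therefore not tied to a single fluorine placement or chain length. No supporting data account for either step.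

The step from the earlier fluorophenyl sulfonyl compound to the new one changes fluorine placement and chain length together, and the compounds shown cannot separate these two changes or say whether one offsets the other. Also open, on these data alone, is how far the position depends on the fluorophenyl sulfonyl group itself, as would be tested by an unsubstituted phenyl ring, a carboxamide in place of the sulfonyl amino link, or a longer chain.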